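This account rests on a few compounds, and the source may have more. Where it says the series, first, only, none or still open, it means among the compounds named here.

Measured so far:
- compound 1, `Cc1nc(C)c2c(n1)N(Cc1ccc(-c3ccccc3-c3nn[nH]n3)cn1)C(=O)CC2`: -34%
- compound 2, `CCc1nc(C)c2c(n1)N(Cc1ccc(-c3ccccc3-c3nn[nH]n3)cc1)C(=O)CC2`: -76%

Both were run in a functional assay on the whole organism (artery) with Rattus norvegicus as the target, with a stated time of 60 min, at a dose of 3 mg/kg by the intraduodenal route; on this read-out lower numbers stand for less inhibition and higher numbers for more inhibition at the one dose given (going by the name of the read-out). On that read-out compound 2 gives -76%, the lower of the two numbers; compound 1 gives -34%, a number beyond the scatter higher. The two compounds differ in more than one place, so their gap is not tied to any single change.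

Compound 3, `Cc1nc(C(C)C)nc2c1CCC(=O)N2Cc1ccc(-c2ccccc2-c2nn[nH]n2)cc1`, is not yet measured in this assay. It differs from compound 2 by methyl in place of hydrogen on a saturated chain carbon bound to an aromatic carbon and a saturated chain carbon. Going by these compounds, nothing measured isolates a change of this kind, so the size of the step is unknown from the data. The expectation is a step from compound 2 to compound 3 of a number 11 percentage points higher from compound 2 to compound 3 (beyond the scatter), with no direction that the data support beyond the scatter. Compound 3 is estimated to give -65% in this assay, expected within -100% to -25%.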

Compound 3, a percentage reported as inhibition, in the whole organism at one dose (the size of the read-out at that dose, not a potency): -40%
Compound 3: middle estimate off by 25 percentage points, on the low side; measured number inside the range.
By their numbers in this assay, from the lowest: compound 2; then compounds 3 and 1 (each within the scatter of the next).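

Going from ethyl to isopropyl gives a number 36 percentage points higher from compound 2 to compound 3 (beyond the scatter) in this assay, and this is the first step in the series that can be tied to one place. One methyl in place of hydrogen, on a saturated chain carbon bound to an aromatic carbon and a saturated chain carbon, is enough to move this whole-animal read-out by a large amount, so the group at this position cannot be treated as interchangeable. Nothing available explains the size of the step.

With only ethyl and isopropyl compared here, the trend at this position remains undefined: a longer chain such as propyl, or a cyclopropyl group, could fall anywhere relative to them. Going by these compounds, whether the same change would give a similar step on the core of compound 1 also remains open.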